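Fluoro to hydrogen on the fused ring of compound 3

The compounds below may be only part of what the source reports. "The series", "measured", "known", "first", "only" and "open" are said of these compounds alone.

Values in an assay on isolated protein for inhibition of alkaline phosphatase, tissue-nonspecific isozyme (Bos taurus), read by spectrophotometry, with stated times of 10 min and 30 min; a lower number here means a stronger inhibitor, a higher number a weaker inhibitor:
compound 1 `CCOC1Oc2ccc(Br)cc2C(=O)/C1=C\Nc1cccc(S(N)(=O)=O)c1`: 44000 nM
compound 2 `CCOC1Oc2ccc(CC)cc2C(=O)/C1=C\Nc1cccc(S(N)(=O)=O)c1`: 16800 nM
compound 3 `CCOC1Oc2ccc(F)cc2C(=O)/C1=C/Nc1ccc(S(=O)(=O)Nc2nnc(C)s2)cc1`: 21000 nM

Compound 3 holds the second highest of the three numbers. Compound 2 sits nearest; the gap between the two is within the scatter, so no order between compound 2 and compound 3 can be read. Compound 1 is furthest, with a number higher than that of compound 3 by a margin beyond the scatter.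

Compound 4 `CCOC1Oc2ccccc2C(=O)/C1=C/Nc1ccc(S(=O)(=O)Nc2nnc(C)s2)cc1` is not yet measured. It differs from compound 3 in one place: hydrogen in place of fluoro on an aromatic carbon.

Within the data shown here, one measured step bears on this change, since it alters a substituent at the same position of the fused ring: a 2.6-fold lower number from compound 1 to compound 2 (0.42 log units; beyond the scatter). Among the measured compounds shown here, that step replaced one group with another; the present step removes a group altogether and leaves a hydrogen, which no measured pair covers. For the measured compounds named here, the modest size of the step from compound 1 to compound 2 is the only guide to how much this position matters, and it points to a small effect. Compound 4 is therefore expected to land close to compound 3, with a step of a 1.2-fold higher number from compound 3 to compound 4 (0.09 log units; within the scatter) that need not clear the scatter. The estimate for compound 4 in this assay is 26000 nM, in the range 10000 nM to 65000 nM.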

Compound 4, inhibition constant: 250 nM
Compound 4: middle estimate off by 100-fold (2.02 log units), on the high side; the measured number lies below the stated range.
By their numbers in this assay, from the lowest: compound 4; then compounds 2 and 3 (each within the scatter of the next); then compound 1.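

In this assay, hydrogen in place of fluoro on an aromatic carbon gives an 84-fold lower number from compound 3 to compound 4 (1.92 log units; beyond the scatter), a large step for the loss of a single heavy atom, with no hydrogen-bond donor or acceptor counted on either side. Among these compounds, the only earlier step at this position, a 2.6-fold lower number from compound 1 to compound 2 (0.42 log units; beyond the scatter), was modest, but it exchanged one substituent for another in compounds that also differ from compound 3 and compound 4 elsewhere, so it did not show how strongly the number can depend on this place. Nothing measured here accounts for the size of the new step.

Going by these compounds, with the rest of compound 3 held fixed, only fluoro and hydrogen are seen at this position, so it remains open whether the step reflects a general penalty for any substituent there or something particular to fluoro, which a methyl, chloro, methoxy or amine group at the same carbon would help to separate. On these data alone, it is also open whether hydrogen at this carbon would give a step of similar size in the setting of compound 1 and compound 2.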